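The source may hold more compounds than are shown below. What is called first, only, known or untested is meant among the compounds shown, and "the series" means these compounds.

In a physicochemical assay for solubility, in phosphate buffer, measured as kinetic solubility, at pH 7.4 (on this read-out higher numbers stand for higher solubility and lower numbers for lower solubility), compound 1 `Cc1ccccc1-c1nc(CN2CCC(C(=O)NCCCN3CCC(C(C)C)CC3)CC2)c(C)o1` gives > 71 ug/mL, which is a limit and not a number. Compound 2 `Cc1ccccc1-c1nc(CN2CCC(C(=O)NCCCN3CC4CCCC(C4)C3)CC2)c(C)o1` gives > 71 ug/mL, also a limit. Among the compounds with values here, the one measured step, a step that the two limits leave unreadable from compound 1 to compound 2, therefore offers no size to carry forward, and the evidence is only (the limit of > 71 ug/mL in this assay, at which 2 of the 2 values shown sit). Compound 3 `CCCN(CCC)CCNC(=O)C1CCN(Cc2nc(-c3ccccc3C)oc2C)CC1` differs from compound 2 by a group of 7 heavy atoms (6 carbon, 1 nitrogen; no ring) in place of a group of 10 heavy atoms (9 carbon, 1 nitrogen; one six-membered non-aromatic ring of carbon only, one six-membered non-aromatic ring with 1 hetero atom), on a saturated chain carbon, two bonds along the chain from an amide-type nitrogen. With no readable step to draw on, no change beyond the scatter is expected. The estimated step is a step that the limit leaves unreadable from compound 2 to compound 3. Compound 3 is expected at about 75 ug/mL, within an estimated range of 40 ug/mL to 110 ug/mL.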

Compound 3, solubility: > 65 ug/mL
Compound 3: a limit, no number; the forecaster's own chance of this, stated with the estimate: 70%; the middle value lies beyond the limit too.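

Within the data shown here, compound 1, compound 2 and compound 3 all stand as limits in this assay, so no step among them can be read. The compounds shown leave open how far each lies beyond its limit, and whether their differing groups change the read-out at all.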